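The source may hold more compounds than are shown below. What is called first, only, known or untested is meant among the compounds shown, and "the series" means these compounds.

Compound 1 `COc1ccc(NC(=O)C2Cc3cc(OC)c(OC)cc3C2=O)cc1`: 49.5 ug/mL
Compound 2 `COc1cccc(NC(=O)C2Cc3cc(OC)c(OC)cc3C2=O)c1`: 38.9 ug/mL

Both numbers come from a physicochemical assay, with a stated time of 30 min; on this read-out lower numbers stand for stronger inhibition and higher numbers for weaker inhibition. Among the measured compounds shown here, the only measured step is a 1.3-fold lower number from compound 1 to compound 2 (0.10 log units; within the scatter), so compound 1 and compound 2 cannot be ranked against each other. The next compound is compound 3 `COc1cc2c(cc1OC)C(=O)C(C(=O)Nc1cccc(Cl)c1)C2`, which keeps the shared core of compound 2 and changes one group: chloro in place of methoxy on an aromatic carbon, meta to a large group (chloro in place of methoxy on an aromatic carbon). Cut one bond further out, the same difference reads 3-methoxyphenyl to 3-chlorophenyl.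

For the measured compounds named here, no measured pair makes this swap, so there is no direct guide. Going by the values given here, the nearest evidence is the one step above, which changes the same phenyl group, from 4-methoxyphenyl to 3-methoxyphenyl, and stays within the scatter. A single small step is thin support, yet it gives no reason to expect a change beyond the scatter in this assay, in either direction. The estimate therefore starts from compound 2, at 38.9 ug/mL. The expected step is a 1.0-fold higher number from compound 2 to compound 3 (0.01 log units; within the scatter). Compound 3 is estimated at 40 ug/mL, with an expected range from 18 ug/mL to 85 ug/mL.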

Compound 3, half-maximal inhibitory concentration: 76.3 ug/mL
Estimate against measurement, compound 3: 1.9-fold (0.28 log units) below; the measured number falls inside the stated range.
By their numbers in this assay, from the lowest: compounds 2, 1 and 3 (each within the scatter of the next).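

In this assay, the methoxy group on this aromatic carbon, which the earlier pair only moved around the phenyl ring, is now replaced by a chloro group, and this gives a 2.0-fold higher number from compound 2 to compound 3 (0.29 log units; within the scatter) even though a different atom now sits on the ring. Measured against the other methoxy compound, the 3-chlorophenyl group gives a 1.5-fold higher number from compound 1 to compound 3 (0.19 log units; within the scatter) on the amide-type nitrogen, so all three compounds remain unranked and, among these three, neither the place of the methoxy group nor its swap for chloro yields a difference that can be told apart from the scatter of repeated measurements. The data shown offer no independent measurement that could account for where these numbers fall.

The compounds shown carry only a methoxy or a chloro group on this phenyl ring, so it remains open whether a very different group here, such as an amine, a carboxylic acid or a longer chain, would move the number beyond the scatter. Also open, as far as these compounds go, is how a chloro group would behave in the 4-chlorophenyl arrangement, and whether any change to the shared core would matter more than these changes on the phenyl ring.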